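The source may hold more compounds than are shown below. What is called first, only, known or untested is meant among the compounds shown, and "the series" means these compounds.

Of the compounds shown here, three built on one shared core have been measured in a functional assay on B16-F10 cells (Mus musculus) for inhibition, read by MTT assay, with a stated time of 72 h; a lower number here means a stronger inhibitor, a higher number a weaker inhibitor. Compound 1 `CC(C)c1ccc(-c2nc(SCc3cn(CC(=O)NC(=O)Nc4ccccn4)nn3)nc(Nc3ccc(F)cc3)c2C#N)cc1` gives 7250 nM. Compound 2 `CC(C)c1ccc(-c2nc(SCc3cn(CC(=O)NC(=O)Nc4ccccn4)nn3)nc(Nc3cccc(C(F)(F)F)c3)c2C#N)cc1` gives 1700 nM, and compound 3 `CC(C)c1ccc(-c2nc(SCc3cn(CC(=O)NC(=O)Nc4ccccn4)nn3)nc(Nc3ccccc3F)c2C#N)cc1` gives 8380 nM. Compound 3 thus carries the highest number of the three: its nearest neighbour is compound 1, as the change a 1.2-fold higher number from compound 1 to compound 3 (0.06 log units; within the scatter) shows, and its furthest is compound 2, seen in a 4.9-fold higher number from compound 2 to compound 3 (0.69 log units; beyond the scatter). The remaining measured step, a 4.3-fold lower number from compound 1 to compound 2 (0.63 log units; beyond the scatter), is likewise modest.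

Compound 4 `Cc1ccccc1Nc1nc(SCc2cn(CC(=O)NC(=O)Nc3ccccn3)nn2)nc(-c2ccc(C(C)C)cc2)c1C#N` differs from compound 3 in one place: methyl in place of fluoro on an aromatic carbon. None of the three measured steps swaps a fluoro for a methyl; each of them instead changes or moves the group carried by the phenyl on the aromatic nitrogen. The closest comparison is the step between compound 1 and compound 3, which stayed within the scatter, while the two steps involving compound 2 were modest. Among the compounds with values here, with no direct precedent for this exchange, the expected step of a 1.2-fold lower number from compound 3 to compound 4 (0.08 log units; within the scatter) is none beyond the scatter. Compound 4 is estimated at 7000 nM, with a range from 3000 nM to 17000 nM in this assay.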

Compound 4, half-maximal inhibitory concentration: 18600 nM
The estimate for compound 4 lay 2.7-fold (0.42 log units) below the measured number; measured number outside the range, above it.
By their numbers in this assay, from the lowest: compound 2; then compounds 1 and 3 (each within the scatter of the next); then compound 4.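

On the aromatic carbon ortho to a large group, exchanging one heavy atom for another is enough to shift the result in this assay, with methyl in place of fluoro giving a 2.2-fold higher number from compound 3 to compound 4 (0.35 log units; beyond the scatter). The two fluorophenyl compounds had stayed within the scatter of each other and so gave no sign that the choice of group on this phenyl could matter unless a trifluoromethyl group was involved, but the 2-methylphenyl group now stands apart from the 4-fluorophenyl group in a 2.6-fold higher number from compound 1 to compound 4 (0.41 log units; beyond the scatter) and from the 3-(trifluoromethyl)phenyl group in an 11-fold higher number from compound 2 to compound 4 (1.04 log units; beyond the scatter), the latter being a large step. Nothing measured here gives a reason for these steps.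

As far as these compounds go, whether a chlorine atom, a methoxy group or an amine on this same carbon would fall nearer to fluoro or to methyl remains open, as does whether a longer chain such as ethyl would push the number higher still. Also open, from the compounds shown here alone, is whether the exchange of fluoro for methyl gives a step of this size when the rest of the molecule differs.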